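Moving the nitro group: 4-nitrophenyl to 2-nitrophenyl

The source may report more compounds than this note shows. Statements on the series, on what has been measured and on what is new or still open speak of the compounds shown alone.

- compound 1 `CC(=O)O[C@H]1CC[C@]2(C)[C@H](CC[C@@](C)(O)[C@H]2CC[C@@H]2C(C)=CC[C@H]3[C@H](CC[C@]3(C)O)C2(C)C)OC1(C)C` gives 38000 nM
- compound 2 `CC1=CC[C@H]2[C@H](CC[C@]2(C)O)C(C)(C)[C@@H]1CC[C@H]1[C@]2(C)CC[C@H](OC(=O)c3ccccc3)C(C)(C)O[C@H]2CC[C@@]1(C)O` gives 16100 nM
- compound 3 `CC1=CC[C@H]2[C@H](CC[C@]2(C)O)C(C)(C)[C@@H]1CC[C@H]1[C@]2(C)CC[C@H](OC(=O)c3ccc([N+](=O)[O-])cc3)C(C)(C)O[C@H]2CC[C@@]1(C)O` gives 8900 nM

All three values come from a functional assay on MDA-MB-231 cells (Homo sapiens) for antiproliferative activity, read by MTT assay, with a stated time of 72 h; on this read-out lower numbers stand for stronger inhibition and higher numbers for weaker inhibition. Compound 3 stands at the low end of these numbers, with a 4.3-fold lower number from compound 1 to compound 3 (0.63 log units; beyond the scatter) and a 1.8-fold lower number from compound 2 to compound 3 (0.26 log units; within the scatter). The second of these gaps lies within the scatter, so compound 2 and compound 3 cannot be separated.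

The next compound is compound 4 `CC1=CC[C@H]2[C@H](CC[C@]2(C)O)C(C)(C)[C@@H]1CC[C@H]1[C@]2(C)CC[C@H](OC(=O)c3ccccc3[N+](=O)[O-])C(C)(C)O[C@H]2CC[C@@]1(C)O`, with 2-nitrophenyl in place of 4-nitrophenyl on a carbonyl carbon. Among the measured compounds shown here, no measured compound carries 2-nitrophenyl, so no measured step shows this change directly. The nearest evidence is the nitro step, a 1.8-fold lower number from compound 2 to compound 3 (0.26 log units; within the scatter), which stayed within the scatter. Compound 2 also kept its gain over compound 1, a 2.4-fold lower number from compound 1 to compound 2 (0.37 log units; beyond the scatter), with an unsubstituted phenyl, and that gain was modest. Moving the nitro group is therefore expected to cause no step beyond the scatter. The expected step is a 1.2-fold higher number from compound 3 to compound 4 (0.09 log units; within the scatter). For compound 4 the estimated value is 11000 nM, with an expected range from 5500 nM to 22000 nM.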

Compound 4, half-maximal inhibitory concentration: 38700 nM
For compound 4 the middle estimate is 3.5-fold (0.55 log units) below the measured one; measured number outside the range, above it.
By their numbers in this assay, from the lowest: compounds 3 and 2 (each within the scatter of the next); then compounds 1 and 4 (each within the scatter of the next).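

In this assay, the place of the nitro group on the ring matters: 2-nitrophenyl in place of 4-nitrophenyl, with the same atoms, gives a 4.3-fold higher number from compound 3 to compound 4 (0.64 log units; beyond the scatter). Adding nitro to the plain phenyl now gives a 2.4-fold higher number from compound 2 to compound 4 (0.38 log units; beyond the scatter), although the same addition in the 4-nitrophenyl compound stayed within the scatter, so this addition can weaken the read-out or leave it unresolved depending on where it lands. Compared with the methyl group, 2-nitrophenyl gives a 1.0-fold higher number from compound 1 to compound 4 (0.01 log units; within the scatter), so the gain seen with phenyl and 4-nitrophenyl is absent in compound 4.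

No measurement here accounts for this dependence on position. Going by these compounds, it also remains open whether an amine or a carboxylic acid in place of the nitro group would follow the same dependence on position.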